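The compounds below may be only part of what the source reports. "The series", "measured", "known", "first", "only" and "open" are said of these compounds alone.

Measured so far:
- compound 1, `O=C(O)c1ccccc1-c1ccc(CCc2ncc(CC3CCCCCC3)[nH]2)cc1`, 5.7 nM
- compound 2, `Cc1cccc(Cc2cnc(CCc3ccc(-c4ccccc4C(=O)O)cc3)[nH]2)c1`, 75 nM
- compound 3, `O=C(O)c1ccccc1-c1ccc(CCc2ncc(Cc3ccc(F)cc3)[nH]2)cc1`, 50 nM

All three values come from an in vitro functional assay on cells for agonist activity at Bombesin receptor subtype-3 (Mus musculus), read by luminescence and calcium flux; on this read-out higher numbers stand for an effect only at larger amounts of compound and lower numbers for an effect already at smaller amounts. Compound 1 gives the lowest number of the three; compound 3 lies nearest to it and compound 2 furthest, both beyond the scatter.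

The step to compound 4, `CC(C)CCc1cnc(CCc2ccc(-c3ccccc3C(=O)O)cc2)[nH]1`, changes the same place on the shared core that is changed in the two measured steps: isobutyl in place of cycloheptyl on a saturated chain carbon bound to an aromatic carbon. The measured steps at this place are a 13-fold higher number from compound 1 to compound 2 (1.12 log units; beyond the scatter) and an 8.8-fold higher number from compound 1 to compound 3 (0.94 log units; beyond the scatter), the 4-fluorophenyl and 3-methylphenyl analogues lying within the scatter of each other (a 1.5-fold lower number from compound 2 to compound 3 (0.18 log units; within the scatter)). Both replacements of cycloheptyl raised the number well beyond the scatter. Isobutyl is not an aryl group, so the analogy is loose, but no measured change at this place has kept the number of compound 1, and the expectation is a rise of similar order, an 8.8-fold higher number from compound 1 to compound 4 (0.94 log units; beyond the scatter). Compound 4 is therefore estimated at 50 nM, range 12 nM to 200 nM.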

Compound 4, half-maximal effective concentration: 10 nM
Compound 4: the middle estimate sits 5.0-fold (0.70 log units) above what was measured; measured number below the stated range.
By their numbers in this assay, from the lowest: compounds 1 and 4 (each within the scatter of the next); then compounds 3 and 2 (each within the scatter of the next).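

In this assay isobutyl is the one replacement of cycloheptyl shown that stays within the scatter, with a 1.8-fold higher number from compound 1 to compound 4 (0.24 log units; within the scatter) as the step, so a ring in this group is not required at this place for a number in the range of compound 1. Isobutyl also stands apart from both aryl replacements, with a 5.0-fold lower number from compound 3 to compound 4 (0.70 log units; beyond the scatter) and a 7.5-fold lower number from compound 2 to compound 4 (0.88 log units; beyond the scatter) as its steps, so the earlier rise goes with the 4-fluorophenyl and 3-methylphenyl groups and not with the loss of cycloheptyl as such. Nothing available explains this split between the saturated and aryl groups.

The compounds shown leave open whether a shorter saturated group such as ethyl or a smaller ring such as cyclopentyl keeps the number of compound 1. They also leave open how an amine or a hydroxyl on the isobutyl chain would read.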